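Swapping a Pyrazole Amide for an Acetylpyrrolidine Amide

This account rests on a few compounds, and the source may have more. Where it says the series, first, only, none or still open, it means among the compounds named here.

Compound 3 `Cn1cc(NC(=O)c2ccncc2Nc2cc(-c3ccc4ccn(C)c4c3)c3nccnc3c2)cn1` gives 26500 nM in an assay on lysate for inhibition of 6-phosphofructo-2-kinase/fructose-2,6-bisphosphatase 3 (Homo sapiens), with stated times of 0.5 min and 45 min (a lower number here means a stronger inhibitor, a higher number a weaker inhibitor), the highest of the two numbers in hand; compound 1 `CN1CCC(CNS(=O)(=O)c2ccccc2Nc2cc(-c3ccc4ccn(C)c4c3)c3nccnc3c2)C1` gives 4640 nM. Compound 2 `CN(Cc1cncnc1)S(=O)(=O)c1ccccc1Nc1cc(-c2ccc3ccn(C)c3c2)c2nccnc2c1` reaches only a limit of this assay, > 100000 nM. Compound 4 `CC(=O)N1CCC(NC(=O)c2ccncc2Nc2cc(-c3ccc4ccn(C)c4c3)c3nccnc3c2)C1` differs from compound 3 in one place: 1-acetylpyrrolidin-3-yl in place of 1-methyl-1H-pyrazol-4-yl on an amide-type nitrogen. For the measured compounds named here, the only measured step, an at least 21-fold higher number from compound 1 to compound 2 (1.33 log units; beyond the scatter), sits on a sulfonyl sulfur rather than an amide-type nitrogen and runs from a non-aromatic ring to an aromatic one, the reverse of this change, so it bears only loosely here; its full size stays unknown because it ends at the limit (the limit of > 100000 nM in this assay, at which 1 of the 3 values shown sits). A modest gain is expected, and compound 4 is estimated at 15000 nM, between 4000 nM and 60000 nM. That amounts to an expected step of a 1.8-fold lower number from compound 3 to compound 4 (0.25 log units; within the scatter).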

Compound 4, half-maximal inhibitory concentration: > 100000 nM
Compound 4 was reported as a limit; the forecaster's own chance of this, stated with the estimate: 15%; middle value at least 6.6-fold (0.82 log units) away from the limit.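

Putting 1-acetylpyrrolidin-3-yl in place of 1-methyl-1H-pyrazol-4-yl on this amide-type nitrogen gives, in this assay, an at least 3.7-fold higher number from compound 3 to compound 4 (0.57 log units; beyond the scatter). As far as these compounds go, compound 4 gives > 100000 nM, which is a limit, so the full size of this step stays unknown. The earlier step, an at least 21-fold higher number from compound 1 to compound 2 (1.33 log units; beyond the scatter), ran from a non-aromatic ring to an aromatic one on a sulfonyl sulfur, so these two pairs show no general preference for either ring type.

From the compounds shown here alone, whether the acetyl group or the pyrrolidine ring carries the weakening stays open. An unsubstituted pyrrolidin-3-yl, with its free amine, on this nitrogen could separate the two.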